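Swapping the Ethoxy Group for a Cyclopropyl Ring

This account rests on a few compounds, and the source may have more. Where it says the series, first, only, none or still open, it means among the compounds named here.

Measured compounds:
compound 1, `COC(CC(=O)O)c1ccc(OCc2cccc(-c3c(C)cccc3C)c2)s1`, 210 nM
compound 2, `CCO[C@@H](CC(=O)O)c1ccc(OCc2cccc(-c3c(C)cccc3C)c2)s1`, 40100 nM
compound 3, `CCO[C@H](CC(=O)O)c1ccc(OCc2cccc(-c3c(C)cccc3C)c2)s1`, 50 nM

All three were tested in a functional assay on cells for agonist activity at Free fatty acid receptor 1 (Homo sapiens), read by calcium flux; on this read-out lower numbers stand for an effect already at smaller amounts and higher numbers for an effect only at larger amounts of compound. Compound 3 gives the lowest number of the three: the move a 4.2-fold lower number from compound 1 to compound 3 (0.62 log units; beyond the scatter) is modest, while the move an 800-fold lower number from compound 2 to compound 3 (2.90 log units; beyond the scatter) is large. Compounds 2 and 3 have the same atoms and bonds and differ only in how the one stereocentre is drawn (the fact that compounds 2 and 3 differ only in the configuration as drawn), so this large gap comes from configuration alone.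

Compound 4, `Cc1cccc(C)c1-c1cccc(COc2ccc(C(CC(=O)O)C3CC3)s2)c1`, is the next step. It differs from compound 3 in one place: 2-carboxy-1-cyclopropylethyl in place of 2-carboxy-1-ethoxyethyl on an aromatic carbon. The three measured steps all touch this same side chain at this same place. The two steps from the methoxy compound, a 190-fold higher number from compound 1 to compound 2 (2.28 log units; beyond the scatter) and a 4.2-fold lower number from compound 1 to compound 3 (0.62 log units; beyond the scatter), show that a small change in this chain can move the number far in either direction, and the step of an 800-fold lower number from compound 2 to compound 3 (2.90 log units; beyond the scatter) shows how much the configuration alone counts. Compound 4 carries no defined stereocentre, so it cannot be matched to compound 3 in that respect. On balance, the expectation for compound 4 is a modest rise, a 4.0-fold higher number from compound 3 to compound 4 (0.60 log units; beyond the scatter). The estimated value for compound 4 is 200 nM, within a range from 50 nM to 1000 nM.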

Compound 4, half-maximal effective concentration: 3920 nM
The estimate for compound 4 lay 20-fold (1.29 log units) below the measured number; the measured number lies above the stated range.
By their numbers in this assay, from the lowest: compound 3; then compound 1; then compound 4; then compound 2.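

The side chain that enters has the same count of heavy atoms as the one that leaves, with one hydrogen-bond acceptor fewer, yet in this assay the result is a 78-fold higher number from compound 3 to compound 4 (1.89 log units; beyond the scatter), so a matching heavy-atom count does not hold the number steady at this position. Compound 1 and compound 4 are both drawn without a defined configuration, and that pair shows the same direction, with a 19-fold higher number from compound 1 to compound 4 (1.27 log units; beyond the scatter), so cyclopropyl also gives a higher number than methoxy in a comparison with no drawn difference in configuration. Against the other ethoxy form the result is a 10-fold lower number from compound 2 to compound 4 (1.01 log units; beyond the scatter), which places compound 4 between two forms whose gap rests on configuration alone: the fact that compounds 2 and 3 differ only in the configuration as drawn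

Compound 4 as drawn leaves open what number each of its two separate configurations would give, and so how much of the rise belongs to the cyclopropyl ring itself. A propyl chain or a cyclopropoxy group at the same place would help show whether the ring or the missing oxygen counts for more.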